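Swapping Methoxy for Trifluoromethyl on the Amide Aryl Ring

The compounds below may be only part of what the source reports. "The series", "measured", "known", "first", "only" and "open" are said of these compounds alone.

Of the compounds shown here, three built on one shared core have been tested in a functional assay on cells for positive allosteric modulation of metabotropic glutamate receptor 5 (Rattus norvegicus), read by calcium flux; a lower number here means that less compound is needed, a higher number that more compound is needed for the effect. Compound 1 `COc1cccc(C(=O)Nc2cc(-c3ccccc3)nn2-c2ccccc2)c1` gives 102 nM. Compound 2 `O=C(Nc1cc(-c2ccccc2)nn1-c1ccccc1)c1cccc(C(F)(F)F)c1` gives 228 nM in this assay. Compound 3 `COc1ccc(C(=O)Nc2cc(-c3ccccc3)nn2-c2ccccc2)cc1` gives 54 nM in this assay, the lowest of the three numbers. The step of a 1.9-fold lower number from compound 1 to compound 3 (0.28 log units; within the scatter) lies within the usual scatter, so compounds 1 and 3 cannot be told apart with confidence, whereas the step of a 4.2-fold lower number from compound 2 to compound 3 (0.63 log units; beyond the scatter) lies beyond it.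

Compound 4 `O=C(Nc1cc(-c2ccccc2)nn1-c1ccccc1)c1ccc(C(F)(F)F)cc1` is compound 3 with a single change: trifluoromethyl in place of methoxy on an aromatic carbon. Going by the values given here, one measured step bears directly on this swap, since the same exchange on the same ring, though at another position, gave a 2.2-fold higher number from compound 1 to compound 2 (0.35 log units; beyond the scatter). The other steps, a 1.9-fold lower number from compound 1 to compound 3 (0.28 log units; within the scatter) and a 4.2-fold lower number from compound 2 to compound 3 (0.63 log units; beyond the scatter), only move the group around the ring or change two things at once, so they offer less guidance.

On the strength of that one precedent, a modest rise in the number is expected, of about a 2.2-fold higher number from compound 3 to compound 4 (0.35 log units; beyond the scatter). Compound 4 is therefore estimated to give 120 nM in this assay, with a likely range from 50 nM to 300 nM.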

Compound 4, half-maximal effective concentration: 38 nM
For compound 4 the middle estimate is 3.2-fold (0.50 log units) above the measured one; measured number below the stated range.
By their numbers in this assay, from the lowest: compounds 4, 3 and 1 (each within the scatter of the next, the first and the last beyond it); then compound 2.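

In this assay, trifluoromethyl in place of methoxy, para to a large group, gives a 1.4-fold lower number from compound 3 to compound 4 (0.15 log units; within the scatter), so at this place the two groups cannot be told apart, and the rise seen with the earlier pair does not appear. The same exchange therefore does not have one fixed effect on this ring, and its outcome depends on where it is made: the same change on two cores in this assay, a 2.2-fold higher number (0.35 log units; beyond the scatter) from compound 1 to compound 2 and a 1.4-fold lower number (0.15 log units; within the scatter) from compound 3 to compound 4, 3.2-fold (0.50 log units) apart, beyond the scatter of two such steps. The 4-(trifluoromethyl)phenyl amide in place of the 3-(trifluoromethyl)phenyl amide gives a 6.0-fold lower number from compound 2 to compound 4 (0.78 log units; beyond the scatter), which shows that moving this one group around the ring matters far more than the exchange at this position, while a 2.7-fold lower number from compound 1 to compound 4 (0.43 log units; beyond the scatter) changes both the group and its place, so that step cannot be credited to either change alone.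

As far as these compounds go, only methoxy and trifluoromethyl appear here at each of the two ring positions, so it remains open how an amine, a carboxylic acid or a longer chain such as butoxy would read at the position of compound 4. The rest of the shared core is the same in all four compounds, so these compounds cannot tell whether the pattern would hold on a different core.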